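Side-chain swaps on a shared core: expectation for compound 4

The compounds below may be only part of what the source reports. "The series", "measured", "known", "first", "only" and "open" are said of these compounds alone.

Compound 2 `CCO/C(O)=C1\C(COCCNC(=O)c2ccc(O)nc2)=NC(C)=C(C(=O)OC)C1c1ccccc1Cl` holds the lowest number of the three measured in a functional assay (aorta) with Rattus norvegicus as the target (a higher number here means a weaker inhibitor, a lower number a stronger inhibitor), with compound 2 giving 6.31 nM; compound 1 `CCO/C(O)=C1\C(COCCNC(C)=O)=NC(C)=C(C(=O)OC)C1c1ccccc1Cl` gives 15.9 nM, a step of a 2.5-fold lower number from compound 1 to compound 2 (0.40 log units; beyond the scatter), and compound 3 `CCO/C(O)=C1\C(COCCN(C)/C(=N/C)NC#N)=NC(C)=C(C(=O)OC)C1c1ccccc1Cl` gives 25.1 nM. Compound 4 `CCO/C(O)=C1\C(COCC/N=C(\NC#N)NCCN(C)C)=NC(C)=C(C(=O)OC)C1c1ccccc1Cl` differs from compound 2 by a group of 11 heavy atoms (6 carbon, 5 nitrogen; no ring) in place of a group of 10 heavy atoms (6 carbon, 2 nitrogen, 2 oxygen; one six-membered aromatic ring with 1 hetero atom), on a saturated chain carbon, two bonds along the chain from an oxygen on a saturated carbon. The step that bears most directly on this is a 4.0-fold higher number from compound 2 to compound 3 (0.60 log units; beyond the scatter), which likewise traded the ring-bearing group for a group with no ring; the step of a 1.6-fold higher number from compound 1 to compound 3 (0.20 log units; within the scatter) places such a chain close to the plain acetylamino of compound 1. For compound 4 a step of similar size and direction is therefore expected, a 3.2-fold higher number from compound 2 to compound 4 (0.50 log units; beyond the scatter). Compound 4 is estimated at 20 nM, within 8 nM to 50 nM.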

Compound 4, half-maximal inhibitory concentration: 50.1 nM
For compound 4 the middle estimate is 2.5-fold (0.40 log units) below the measured one; measured number outside the range, above it.
By their numbers in this assay, from the lowest: compound 2; then compounds 1, 3 and 4 (each within the scatter of the next, the first and the last beyond it).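

In this assay, the ring-free group of 11 heavy atoms on this saturated chain carbon gives a 7.9-fold higher number from compound 2 to compound 4 (0.90 log units; beyond the scatter), and unlike the smaller ring-free group of compound 3, it also separates from the acetylamino group, with a 3.2-fold higher number from compound 1 to compound 4 (0.50 log units; beyond the scatter). The two ring-free groups are not separated, at a 2.0-fold higher number from compound 3 to compound 4 (0.30 log units; within the scatter), so the added atoms show no distinct effect between them. Nothing available explains these steps. Still open, going by these compounds, is whether a plain benzoylamino group would match compound 2, which would test the need for the ring nitrogen and hydroxyl. A carboxylic acid at the chain end is also untested here.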